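The compounds below may be only part of what the source reports. "The series", "measured", "known", "first", "only" and "open" are said of these compounds alone.

Measured so far in a functional assay on A549 cells (Homo sapiens) for antiproliferative activity, read by MTT assay, with a stated time of 72 h; on this read-out lower numbers stand for stronger inhibition and higher numbers for weaker inhibition:
- compound 1 `COc1cc(-n2cnc3ccc(-c4ccc(Cl)cc4Cl)cc32)cc(OC)c1OC`: compound 1 gives > 10000 nM, which is a limit of the assay and not a number.
- compound 2 `COc1ccc(-c2ccc3ncn(-c4cc(OC)c(OC)c(OC)c4)c3c2)cc1O`: compound 2 gives 200 nM.

For the measured compounds named here, compound 2 therefore stands as the only numeric value; the other entry is a limit (the limit of > 10000 nM in this assay, at which 1 of the 2 values shown sits). Going by the values given here, the single measured step is an at least 50-fold lower number from compound 1 to compound 2 (1.69 log units; beyond the scatter), a large move from the limit to a measured number on changing the group on the shared core.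

Compound 3 `COc1cc(-n2cnc3ccc(-c4cccc(Cl)c4)cc32)cc(OC)c1OC` is not yet measured. Its change from compound 2 is 3-chlorophenyl in place of 3-hydroxy-4-methoxyphenyl on an aromatic carbon. This runs the measured step partly backwards: the 3-hydroxy-4-methoxyphenyl that brought the large gain in an at least 50-fold lower number from compound 1 to compound 2 (1.69 log units; beyond the scatter) leaves, and a chlorophenyl returns, though with one chlorine and not the 2,4-dichlorophenyl of compound 1. The expectation is therefore a large rise in the number for compound 3, estimated as a 25-fold higher number from compound 2 to compound 3 (1.40 log units; beyond the scatter), with a real chance that only a limit is recorded. Compound 3 is estimated at 5000 nM, within 1000 nM to 20000 nM.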

Compound 3, half-maximal inhibitory concentration: 7050 nM
The estimate for compound 3 lay 1.4-fold (0.15 log units) below the measured number; the range from low to high includes it.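

When 3-hydroxy-4-methoxyphenyl leaves this aromatic carbon of the shared core and 3-chlorophenyl enters, this assay shows a 35-fold higher number from compound 2 to compound 3 (1.55 log units; beyond the scatter), so the gain does not survive on a phenyl ring that carries one chlorine and neither the hydroxyl nor the methoxy. Taking 3-chlorophenyl in place of 2,4-dichlorophenyl gives an at least 1.4-fold lower number from compound 1 to compound 3 (0.15 log units; that floor lies within the scatter), so the data do not separate these two chlorinated rings, and of the three groups shown only 3-hydroxy-4-methoxyphenyl gives a low number. Compound 1 is a limit of the assay and not a number, so this comparison offers only a floor: the limit of > 10000 nM in this assay, at which 1 of the 3 values shown sits.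

Still open, going by these compounds, is whether the hydroxyl, the methoxy or the two together carry the gain, a question that a 3-hydroxyphenyl or a 4-methoxyphenyl group at the same carbon would address. Also open is how a ring bearing an amine or a carboxylic acid would read at this carbon in this assay, as the compounds shown cover only chlorine, hydroxyl and methoxy there.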